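The source may report more compounds than this note shows. Statements on the series, on what has been measured and on what is new or still open speak of the compounds shown alone.

Measured so far:
- compound 1, `CCc1nc2c(C)cc(C)nc2n1Cc1ccc(-c2ccccc2C2=NOS(=O)N2)cc1`: 5.7
- compound 2, `CCc1nc2c(C)cc(C)nc2n1Cc1ccc(-c2ccccc2C2=NN(c3ccccc3)[S+]([O-])N2)cc1`: 7.1

In a physicochemical assay for acid dissociation, compound 2 stands highest of the two numbers. For the measured compounds named here, the only measured step, a number 1.40 log units higher from compound 1 to compound 2 (beyond the scatter), is the one that bears on the change now made, and it shows that exchanging the ring on this aromatic carbon moved the number by a large amount.

Compound 3 is `CCc1nc2c(C)cc(C)nc2n1Cc1ccc(-c2ccccc2C2Nc3ccccc3S(=O)(=O)N2)cc1`. It differs from compound 2 in a group of 12 heavy atoms (7 carbon, 2 nitrogen, 2 oxygen, 1 sulfur; one six-membered non-aromatic ring with 3 hetero atoms, one six-membered aromatic ring of carbon only) in place of a group of 12 heavy atoms (7 carbon, 3 nitrogen, 1 oxygen, 1 sulfur; one five-membered non-aromatic ring with 4 hetero atoms, one six-membered aromatic ring of carbon only), on an aromatic carbon, ortho to a large group.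

Another ring exchange at the same place is therefore expected to shift the number again, and upward, so compound 3 is estimated at 8.5, within 7 to 10. The expected step is a number 1.40 log units higher from compound 2 to compound 3 (beyond the scatter).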

Compound 3, acid dissociation constant: > 10.5
Compound 3: only a limit was reported (the forecaster's own chance of this, stated with the estimate: 5%); at least 2.00 log units between middle value and limit.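

In this assay, exchanging the ring on this aromatic carbon can shift the number much more than the two earlier compounds revealed: there is a number at least 3.40 log units higher from compound 2 to compound 3 (beyond the scatter), and a number at least 4.80 log units higher from compound 1 to compound 3 (beyond the scatter). Compound 3 gives > 10.5, which is a limit and not a number: the limit of > 10.5 in this assay, at which 1 of the 3 values shown sits. Both earlier rings are five-membered with 4 hetero atoms, whereas the ring entering here is six-membered with 3 hetero atoms, so ring size and ring atoms change together.

Which of these two changes accounts for the shift stays open. So does whether a carboxylic acid on this aromatic carbon would read nearer compound 1 or compound 2.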